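Solubility Expected After Changing the Amide Substituent

The compounds below may be only part of what the source reports. "The series", "measured", "known", "first", "only" and "open" are said of these compounds alone.

Compound 1 `CCOc1cc(NC(=O)C2(NC(=O)c3ccc4c(C5CCCC5)c(-c5ncc(Cl)cn5)n(C)c4c3)CCC2)ccc1/C=C/C(=O)OCCOCCOC` is one of the two measured compounds. In an ADME assay for solubility (a lower number here means a less soluble compound, a higher number a more soluble compound), compound 1 gives only a limit, < 100000 ug/mL, not a number. Compound 1 thus sits at the limit of < 100000 ug/mL in this assay, at which 1 of the 2 values shown sits. Compound 2 `CCOc1cc(NC(=O)C2(NC(=O)c3ccc4c(C5CCCC5)c(-c5ncc(Cl)cn5)n(C)c4c3)CCC2)ccc1/C=C/C(=O)OCC(N)=O` carries a carbamoyl group where compound 1 carries a (2-methoxyethoxy)methyl group, and in this assay compound 2 gives 200000 ug/mL. The measured change is an at least 2.0-fold higher number from compound 1 to compound 2 (0.30 log units; that floor lies within the scatter). Within the data shown here, compound 2 therefore stands as the only compound with an actual number; the other value is a limit.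

Compound 3 `CCCN(C)C(=O)COC(=O)/C=C/c1ccc(NC(=O)C2(NC(=O)c3ccc4c(C5CCCC5)c(-c5ncc(Cl)cn5)n(C)c4c3)CCC2)cc1OCC` differs from compound 2 by methyl(propyl)amino in place of amino on a carbonyl carbon. Among the measured compounds shown here, the single measured step, from compound 1 to compound 2, alters the same chain but with a different entering group, and its floor lies within the scatter, so it offers little guidance. For compound 3 the expected step of a 1.3-fold lower number from compound 2 to compound 3 (0.12 log units; within the scatter) is small, within the scatter. The estimate for compound 3 in this assay is 150000 ug/mL, with a range from 60000 ug/mL to 300000 ug/mL.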

Compound 3, solubility: < 200000 ug/mL
Compound 3 was reported as a limit; the forecaster's own chance of this, stated with the estimate: 35%; the middle value lies beyond the limit too.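

At the carbonyl carbon, methyl(propyl)amino in place of amino gives, in this assay, a number no higher from compound 2 to compound 3 (the limit leaves the size open). Among these compounds, this is the first look at a change to this group itself, with amino, which has 1 hydrogen-bond donor, replaced by a group with 0 hydrogen-bond donors, but compound 3 gives a limit, not a number: the limit of < 200000 ug/mL in this assay, at which 1 of the 3 values shown sits. Compound 1 and compound 3 both give limits, and the step between them cannot be read.

From the compounds shown here alone, it remains open how large the step from amino to methyl(propyl)amino really is, and whether the methyl or the propyl part matters more. Going by these compounds, it is also open whether a shorter group on this carbonyl carbon, such as methylamino or dimethylamino, would give an actual number in this assay.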